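Extending the sulfonyl substituent: from compound 3 to compound 4

The compounds below may be only part of what the source reports. "The series", "measured", "known", "first", "only" and "open" are said of these compounds alone.

Measured compounds:
- compound 1, `CC(C)c1cccc(C(C)C)c1NC(=O)NS(=O)(=O)N(C)C`: 3900 nM
- compound 2, `C=CCN(CC=C)S(=O)(=O)NC(=O)Nc1c(C(C)C)cccc1C(C)C`: 2700 nM
- compound 3, `CCCCN(CC)S(=O)(=O)NC(=O)Nc1c(C(C)C)cccc1C(C)C`: 1200 nM

In an assay on liver for inhibition of sterol O-acyltransferase 1 (Rattus norvegicus), using microsomes (on this read-out higher numbers stand for weaker inhibition and lower numbers for stronger inhibition), compound 3 gives the lowest number of the three measured compounds, and its separation from each of the others lies beyond the scatter, so among these three it is the strongest inhibitor. The measured steps all change the group on the sulfonyl sulfur: a 1.4-fold lower number from compound 1 to compound 2 (0.16 log units; within the scatter), a 3.3-fold lower number from compound 1 to compound 3 (0.51 log units; beyond the scatter) and a 2.3-fold lower number from compound 2 to compound 3 (0.35 log units; beyond the scatter). The picture so far is that a larger group on the sulfonyl sulfur goes with a lower number, though compound 2 sits close to compound 1 in spite of its larger group.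

Compound 4, `CCCCCCC(C)OS(=O)(=O)NC(=O)Nc1c(C(C)C)cccc1C(C)C`, carries a further change at the same place: (1-methylheptyl)oxy in place of butyl(ethyl)amino on a sulfonyl sulfur. Among the compounds with values here, the entering group is larger than the one it replaces, which points the same way as the steps from compound 1 to compound 3, but no measured pair swaps a nitrogen for an oxygen on the sulfonyl sulfur, so that part of the change has no precedent here. The expectation is a modest step down in this assay, a 1.7-fold lower number from compound 3 to compound 4 (0.23 log units; within the scatter), with considerable uncertainty. Compound 4 is therefore estimated at 700 nM, within a range from 200 nM to 3000 nM.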

Compound 4, half-maximal inhibitory concentration: 35000 nM
Beside the measured number, compound 4's estimate is 50-fold (1.70 log units) below it; the whole stated range lies below it.
By their numbers in this assay, from the lowest: compound 3; then compounds 2 and 1 (each within the scatter of the next); then compound 4.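

In this assay, (1-methylheptyl)oxy on the sulfonyl sulfur gives the first large rise in the number at this position, with a 29-fold higher number from compound 3 to compound 4 (1.46 log units; beyond the scatter) and a 13-fold higher number from compound 2 to compound 4 (1.11 log units; beyond the scatter) as well as a 9.0-fold higher number from compound 1 to compound 4 (0.95 log units; beyond the scatter) in the same direction. Compound 4 is thus the weakest inhibitor of the four, even though the group it carries has more heavy atoms than butyl(ethyl)amino, so the earlier link between a larger group and a lower number, already loose at compound 2, does not hold for compound 4. No measurement shown here accounts for this reversal.

The change replaces the nitrogen attached to the sulfonyl sulfur with an oxygen and alters the carbon chain at the same time, so the compounds shown cannot separate the effect of the attached atom from that of the chain. A (1-methylheptyl)amino group, or a shorter butoxy group, on the same sulfonyl sulfur would pull these two parts of the change apart.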